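The source may report more compounds than this note shows. Statements on the series, on what has been measured and on what is new or still open speak of the compounds shown alone.

In a functional assay on HL-60 cells (Homo sapiens) for antiproliferative activity (on this read-out higher numbers stand for weaker inhibition of growth and lower numbers for stronger inhibition of growth), compound 1 `COCCCCCCCCCCCCCCC/C=C1\CC(CO)(COC(=O)C(C)(C)C)OC1=O` gives 4.65 ug/mL and compound 2 `COCCCCCCCCCCC/C=C1\CC(CO)(COC(=O)C(C)(C)C)OC1=O` gives 5.22 ug/mL, and the comparison between them is a 1.1-fold higher number from compound 1 to compound 2 (0.05 log units; within the scatter). Compound 3 `CC(C)(C)C(=O)OCC1(CO)C/C(=C\CCCCCCCCCCCO)C(=O)O1` gives > 10 ug/mL, which is a limit of the assay and not a number. This is the limit of > 10 ug/mL in this assay, at which 1 of the 3 values shown sits.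

Compound 4 `CC(=O)OCCCCCCCCCCCCCCC/C=C1\CC(CO)(COC(=O)C(C)(C)C)OC1=O` is still unmeasured. Its change from compound 3 is 4-acetoxybutyl in place of hydroxy on a saturated chain carbon, ten or more bonds along the chain from a double-bonded chain carbon.

The closest measured comparison replaces the same hydroxy with 4-methoxybutyl, and read in reverse it suggests a gain in growth inhibition: an at least 2.1-fold higher number from compound 1 to compound 3 (0.33 log units; beyond the scatter). A second comparison points the same way, though its floor is weaker: an at least 1.9-fold higher number from compound 2 to compound 3 (0.28 log units; that floor lies within the scatter). Among the measured compounds shown here, because the first of these rests on compound 1 with 4.65 ug/mL, a similar move toward a lower number is expected here, assuming the acetoxy end behaves like the methoxy end, which no measurement yet tests. The expected step is an at least 2.0-fold lower number from compound 3 to compound 4 (0.30 log units; that floor lies within the scatter). For compound 4 the estimated value is 5 ug/mL, with an expected range of 2.5 ug/mL to 10 ug/mL.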

Compound 4, concentration for 50% growth inhibition: > 10 ug/mL
Compound 4 was reported as a limit; the forecaster's own chance of this, stated with the estimate: 15%; at least 2.0-fold (0.30 log units) between middle value and limit.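

On this assay, putting acetyl in place of the methyl on the oxygen at the chain end costs growth inhibition, a change beyond the scatter: an at least 2.1-fold higher number from compound 1 to compound 4 (0.33 log units; beyond the scatter). Putting 4-acetoxybutyl in place of methoxy leans the same way, less firmly: an at least 1.9-fold higher number from compound 2 to compound 4 (0.28 log units; that floor lies within the scatter). So a free hydroxy end, as in compound 3, is not the only chain end that gives a result at the limit of the assay, and the step from compound 3 to compound 4 cannot be read, as both are limits and not numbers: the limit of > 10 ug/mL in this assay, at which 2 of the 4 values shown sit.

Going by these compounds, how much weaker compound 3 and compound 4 really are remains open, as does whether the methoxy end itself is needed. An ethoxy group, an amine or a carboxylic acid at the same place could help settle how narrow this requirement is.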